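Exchanging the Aryl Group on the Sulfonyl Sulfur

A few compounds are considered here, and "the series" means these few. Any claim that something is new, unique, unknown or untested is made for them only; others in the source may bear on it.

Compound 1 `CCc1ccc(S(=O)(=O)N2CCC(N3CCC(C)CC3)CC2)cc1` is the starting point. In a functional assay on DLD-1 cells (Homo sapiens) for antiproliferative activity, read by CellTiter-Glo, with a stated time of 72 h (a lower number here means a stronger inhibitor, a higher number a weaker inhibitor), compound 1 gives > 5000 nM, which is a limit of the assay rather than a measured number, so compound 1 sits at the weak end of what can be reported. Two close relatives show what happens when the ethyl group on the aromatic carbon is exchanged for an alkoxy group. Compound 2 `CCCCOc1ccc(S(=O)(=O)N2CCC(N3CCC(C)CC3)CC2)cc1` gives 2300 nM in this assay, and compound 3 `CCCOc1ccc(S(=O)(=O)N2CCC(N3CCC(C)CC3)CC2)cc1` gives 452 nM. The step of an at least 2.1-fold lower number from compound 1 to compound 2 (0.33 log units; beyond the scatter) and the step of an at least 11-fold lower number from compound 1 to compound 3 (1.04 log units; beyond the scatter) both run toward stronger inhibition, and between the two alkoxy compounds a 5.1-fold lower number from compound 2 to compound 3 (0.71 log units; beyond the scatter).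

Compound 4 `CC1CCN(C2CCN(S(=O)(=O)c3ccccc3Br)CC2)CC1` is not yet measured. It differs from compound 1 by 2-bromophenyl in place of 4-ethylphenyl on a sulfonyl sulfur. Within the data shown here, none of the measured steps involves a bromine or a change of this kind; they only show that the ethyl group of compound 1 is the least favourable of the three groups tried, with compound 1 sitting at the limit of > 5000 nM in this assay, at which 1 of the 3 values shown sits. Without a comparable step, no change beyond the scatter is expected in either direction in this assay, and compound 4 is estimated at 5000 nM (range 1500 nM to 15000 nM), meaning an expected step of a number no higher from compound 1 to compound 4 (the limit leaves the size open).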

Compound 4, half-maximal inhibitory concentration: 3 nM
For compound 4 the middle estimate is 1700-fold (3.22 log units) above the measured one, and the stated range ends above it.
By their numbers in this assay, from the lowest: compound 4; then compound 3; then compound 2. At a limit, above all of these: compound 1.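

Exchanging 4-ethylphenyl for 2-bromophenyl on a sulfonyl sulfur gives, in this assay, an at least 1600-fold lower number from compound 1 to compound 4 (3.22 log units; beyond the scatter), which is much larger than the change seen among the alkoxy compounds, such as an at least 11-fold lower number from compound 1 to compound 3 (1.04 log units; beyond the scatter). The earlier compounds shown here varied only the chain carried by the aromatic ring, whereas this step shows that replacing that whole group can matter far more, even though the two groups have the same kind of ring, the same hydrogen-bond donor and acceptor counts and no net charge. The value of compound 1 is a limit and not a number, so the step gives only a minimum size: the limit of > 5000 nM in this assay, at which 1 of the 4 values shown sits.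

The compounds shown do not separate the effect of the bromine itself from the effect of where it stands, since 2-bromophenyl differs from 4-ethylphenyl in both respects, and 4-bromophenyl would be needed to tell them apart. From the compounds shown here alone, whether a chlorine, a methoxy group or an amine could take the place of the bromine on this ring and keep the strong inhibition of compound 4 also remains open.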